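A few compounds are considered here, and "the series" means these few. Any claim that something is new, unique, unknown or untested is made for them only; others in the source may bear on it.

Of the compounds shown here, three share a core and have been measured in a functional assay on MCF7 cells (Homo sapiens) for inhibition, read by MTT assay, with a stated time of 72 h; on this read-out higher numbers stand for weaker inhibition and lower numbers for stronger inhibition. Compound 1 `COc1cc(NC(C)CCCNC(=O)NNC(=O)Nc2cc(C(F)(F)F)cc(C(F)(F)F)c2)c2ncccc2c1` gives 2400 nM in this assay, compound 3 `COc1cc(NC(C)CCCNC(=O)Nc2cc(C(F)(F)F)cc(C(F)(F)F)c2)c2ncccc2c1` gives 1600 nM, and compound 2 `COc1cc(NC(C)CCCNC(=O)NNC(=O)Nc2cccc(Cl)c2)c2ncccc2c1` gives 220 nM. Compound 2 stands lowest of the three, well beyond the scatter from both others. Compound 1 and compound 3 differ in whether a carbamoylamino link sits between the urea and the aryl ring, and their two values lie close to one another.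

Compound 4 `COc1cc(NC(C)CCCNC(=O)Nc2ccc(Cl)cc2)c2ncccc2c1` is not yet measured. It differs from compound 2 in one place: 4-chlorophenyl in place of ((3-chlorophenyl)carbamoyl)amino on an amide-type nitrogen. The change removes the link between the urea nitrogen and the chlorophenyl ring and moves the chlorine to a 4-chlorophenyl. Among the measured compounds shown here, no measured pair mirrors this exact change, so the expected step is uncertain. Compound 4 is expected to stay near compound 2, with a step of a 1.4-fold higher number from compound 2 to compound 4 (0.13 log units; within the scatter) of modest size in either direction, most likely not beyond the scatter. The estimate for compound 4 in this assay is 300 nM, ranging from 100 nM to 900 nM.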

Compound 4, half-maximal inhibitory concentration: 12000 nM
Beside the measured number, compound 4's estimate is 40-fold (1.60 log units) below it, and the stated range ends below it.
By their numbers in this assay, from the lowest: compound 2; then compounds 3 and 1 (each within the scatter of the next); then compound 4.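

In this assay, placing 4-chlorophenyl in place of ((3-chlorophenyl)carbamoyl)amino on the amide-type nitrogen gives a 55-fold higher number from compound 2 to compound 4 (1.74 log units; beyond the scatter), so this position is far from indifferent to the change. The earlier compounds shown here gave no sign of this: compound 1 at 2400 nM and compound 3 at 1600 nM lie within the scatter of each other, although they differ in whether the carbamoylamino link is present, so the link's absence does not carry the same weight in these two pairs. Nothing available here accounts for the size of the step.

The step joins the loss of the link with the move of the chlorine, and the compounds shown do not separate the two. On these data alone, it remains open whether a 3-chlorophenyl directly on that amide-type nitrogen would stay near compound 2 or fall close to compound 4.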